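The source may hold more compounds than are shown below. What is called first, only, known or untested is meant among the compounds shown, and "the series" means these compounds.

Measured so far:
compound 1, `C=C1C2=C(C(=O)N1OC)[C@H](O)[C@@](C)(O)[C@H](CCCCC)O2` — 19000 nM
compound 2, `C=C1C2=C(C(=O)N1OC)[C@H](OC(=O)CSc1nc3ccccc3s1)[C@@](C)(O)[C@H](CCCCC)O2` — 11000 nM
compound 3, `C=C1C2=C(C(=O)N1OC)[C@@H](F)[C@@](C)(O)[C@H](CCCCC)O2` — 37000 nM

Of the compounds shown here, three sharing one core have been tested in an ADME assay on HEF cells (Homo sapiens) for cytotoxicity, read by MTT assay, with a stated time of 72 h; a higher number here means a weaker inhibitor, a lower number a stronger inhibitor. Compound 2, `C=C1C2=C(C(=O)N1OC)[C@H](OC(=O)CSc1nc3ccccc3s1)[C@@](C)(O)[C@H](CCCCC)O2`, gives the lowest of the three numbers, 11000 nM. Compound 1, `C=C1C2=C(C(=O)N1OC)[C@H](O)[C@@](C)(O)[C@H](CCCCC)O2`, gives 19000 nM, which lies within the scatter of compound 2, so the two cannot be told apart. Compound 3, `C=C1C2=C(C(=O)N1OC)[C@@H](F)[C@@](C)(O)[C@H](CCCCC)O2`, gives 37000 nM, and its gap to compound 2 is beyond the scatter.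

Compound 4, `C=C1C2=C(C(=O)N1OC)[C@H](OC(=O)CCl)[C@@](C)(O)[C@H](CCCCC)O2`, has not been measured. It differs from compound 2 in one place: chloro in place of (1,3-benzothiazol-2-yl)sulfanyl on a saturated chain carbon bound to a carbonyl carbon. Among the compounds with values here, no measured pair carries this same change, so the size of its effect is not known from these data. Since compound 1 and compound 2 sit within the scatter of each other, a small shift in either direction, probably not beyond the scatter, is expected from compound 2 to compound 4, a 1.4-fold higher number from compound 2 to compound 4 (0.13 log units; within the scatter). Compound 4 is therefore estimated at 15000 nM, with a range from 6000 nM to 40000 nM.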

Compound 4, half-maximal inhibitory concentration: 9100 nM
Compound 4: middle estimate off by 1.6-fold (0.22 log units), on the high side; the range from low to high includes it.
By their numbers in this assay, from the lowest: compounds 4, 2, 1 and 3 (each within the scatter of the next, the first and the last beyond it).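

In this assay, chloro in place of (1,3-benzothiazol-2-yl)sulfanyl on a saturated chain carbon bound to a carbonyl carbon gives a 1.2-fold lower number from compound 2 to compound 4 (0.08 log units; within the scatter), so the ring-bearing group of 10 heavy atoms and a single chlorine cannot be told apart at this place. The change from the free hydroxyl to the chloroacetyl ester, (chloromethyl)carbonyl in place of hydrogen on an oxygen on a saturated carbon, gives a 2.1-fold lower number from compound 1 to compound 4 (0.32 log units; beyond the scatter), a modest step and the first at this oxygen that is printed as beyond the scatter. Nothing shown here accounts for either step.

The compounds shown leave open whether the chlorine matters or the ester alone suffices, a question that a plain acetyl ester, with methyl in place of chloro, would address. They also leave open how an amine or a longer chain on that same carbon would read.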